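This account rests on a few compounds, and the source may have more. Where it says the series, first, only, none or still open, it means among the compounds named here.

Compound 1 `COc1ccc(-c2cc(/C=C/C(=O)c3ccc(N)cc3)[nH]n2)cc1` and compound 3 `COc1ccc(-c2cc(/C=C/C(=O)c3ccc(N)cc3)[nH]n2)cc1OC` share a core and differ in one place, (methoxy in place of hydrogen on an aromatic carbon). In a functional assay on KM12 cells (Homo sapiens) for cytotoxicity, read by sulforhodamine B assay, with a stated time of 48 h, tested at 1 uM (a lower number here means a stronger effect, a higher number a weaker effect of the compound at the concentration tested), compound 1 gives 77%, while compound 3 gives 88%, so the step of a number 11 percentage points higher from compound 1 to compound 3 (beyond the scatter). Compound 2 `COc1ccc(C(=O)/C=C/c2cc(-c3cc(OC)c(OC)c(OC)c3)n[nH]2)cc1OC` differs from compound 1 by more than one place; the difference between the two cores is not broken down here. Compound 2 gives 54% in this assay, the lowest of the three numbers. Compound 4 `COc1cc(C(=O)/C=C/c2cc(-c3cc(OC)c(OC)c(OC)c3)n[nH]2)cc(OC)c1OC` differs from compound 2 by methoxy in place of hydrogen on an aromatic carbon. This is the same kind of change as that from compound 1 to compound 3, though here the place is also meta to a methoxy group. The step of a number 11 percentage points higher from compound 2 to compound 4 (beyond the scatter) is expected to be of similar size to the earlier one, resting on a number 11 percentage points higher from compound 1 to compound 3 (beyond the scatter). For compound 4 an estimate of 65% is expected, between 50% and 80%.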

Compound 4, a percentage reported as activity, at one concentration (the size of the read-out at that concentration, not a potency): 79%
For compound 4 the middle estimate is 14 percentage points below the measured one; low and high end bracket the measured number.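

In this assay methoxy in place of hydrogen on an aromatic carbon again goes with a number 25 percentage points higher from compound 2 to compound 4 (beyond the scatter), a weaker effect at the concentration tested. Set beside the earlier step, the change points the same way on both cores, and the two sizes cannot be told apart: the same change on two cores in this assay, a number 11 percentage points higher (beyond the scatter) from compound 1 to compound 3 and a number 25 percentage points higher (beyond the scatter) from compound 2 to compound 4, 14 percentage points apart, within the scatter of two such steps. For the compounds shown here, this rests on only two pairs, so it shows that the change carried over between these two cores, but not that it would do so on other cores or at other places on the ring.

As far as these compounds go, the substituents varied here are methoxy groups only, so the effect of a hydroxyl group, a fluorine or an ethoxy group at this place remains open. From the compounds shown here alone, whether the step holds at other concentrations or in other cell lines also remains open.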